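This account rests on a few compounds, and the source may have more. Where it says the series, first, only, none or still open, it means among the compounds named here.

Measured compounds:
compound 1 `Cc1cc(C)cc(S(=O)(=O)n2c(SCC(=O)Nc3ccccc3C)nc3ccccc32)c1` — 6150 nM
compound 2 `Cc1cc(C)cc(S(=O)(=O)n2c(OCC(=O)Nc3ccccc3Br)nc3ccccc32)c1` — > 243000 nM

Of the compounds shown here, two have been measured in an ADME assay on MT4 cells (Homo sapiens) for cytotoxicity, read by MTT assay, with a stated time of 5 days; a lower number here means that less compound is tolerated, a higher number that more compound is tolerated. Compound 1 gives 6150 nM in this assay. Compound 2 reaches only the limit of this assay, > 243000 nM, so that for it no number is known, only a bound. This is where one of the two values shown sits, as the limit of > 243000 nM in this assay, at which 1 of the 2 values shown sits, records. On the numbers shown, compound 2 therefore stands at the top of what this assay can report, with compound 1 clearly below it.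

Compound 3 `COC(=O)c1ccc(NC(=O)COc2nc3ccccc3n2S(=O)(=O)c2cc(C)cc(C)c2)c(Cl)c1` has not yet been measured in this assay. It differs from compound 2 in one place: 2-chloro-4-(methoxycarbonyl)phenyl in place of 2-bromophenyl on an amide-type nitrogen. Among the compounds with values here, no pair of measured compounds differing in a single place is available, so the size of this change cannot be read from a measured step. With compound 2 already at the bound, the expected step is an at least 1.2-fold lower number from compound 2 to compound 3 (0.08 log units; that floor lies within the scatter), that is, nothing beyond the scatter, and it is likely that compound 3 will also return only a limit. Compound 3 is expected to give about 200000 nM in this assay, within 60000 nM to 300000 nM.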

Compound 3, half-maximal cytotoxic concentration: 119000 nM
Estimate against measurement, compound 3: 1.7-fold (0.23 log units) above; the measured number falls inside the stated range.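

In this assay, within the data shown here, replacing 2-bromophenyl with 2-chloro-4-(methoxycarbonyl)phenyl on the amide-type nitrogen gives the first readable step at this position: an at least 2.0-fold lower number from compound 2 to compound 3 (0.31 log units; beyond the scatter). The earlier compounds shown here could not show this, as no pair of them differed in a single place, whereas the change now brings the read-out within the measurable range, with compound 3 at 119000 nM. The step is only a minimum, and its full size stays unknown, because the value for compound 2 is a limit and not a number: the limit of > 243000 nM in this assay, at which 1 of the 3 values shown sits.

The compounds shown leave open how the change divides between its two parts, the chlorine taking the place of the bromine and the added methoxycarbonyl group, as both parts arrive together in compound 3. They also leave open how this assay would read with a carboxylic acid or a primary amide in place of that methoxycarbonyl group, and so whether the lower number depends on the ester itself or would appear with other groups there.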